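Swapping an acetamidoethyl amine for a carboxypiperidine

A few compounds are considered here, and "the series" means these few. Any claim that something is new, unique, unknown or untested is made for them only; others in the source may bear on it.

Three measured compounds share one core. Compound 3, `COc1ccc(/C=C\c2cc(OC)c(OC)c(OC)c2)cc1OCc1ccc(CNCCNC(C)=O)cc1`, in an ADME assay on NCM460 cells (Homo sapiens) for cytotoxicity, read by CCK-8 assay, with a stated time of 48 h (a higher number here means a weaker inhibitor, a lower number a stronger inhibitor), gives 54000 nM. Compound 2, `COc1ccc(/C=C\c2cc(OC)c(OC)c(OC)c2)cc1OCc1ccc(C=O)cc1`, in this assay gives 41000 nM, and the step of a 1.3-fold higher number from compound 2 to compound 3 (0.12 log units; within the scatter) lies within the scatter. Compound 1, `COc1ccc(/C=C\c2cc(OC)c(OC)c(OC)c2)cc1OCc1ccc(CN[C@H](C(=O)O)[C@H](C)O)cc1`, in this assay reaches only > 50000 nM, which is a limit rather than a number. Of the two numbers shown, compound 3 gives the higher one, with compound 2 nearest. Compound 4, `COc1ccc(/C=C\c2cc(OC)c(OC)c(OC)c2)cc1OCc1ccc(CN2CCCC[C@@H]2C(=O)O)cc1`, differs from compound 3 by 2-carboxypiperidin-1-yl in place of (2-acetamidoethyl)amino on a saturated chain carbon bound to an aromatic carbon. Going by the values given here, the steps that bear on this change are small: an at least 1.2-fold lower number from compound 1 to compound 2 (0.08 log units; that floor lies within the scatter) and a 1.3-fold higher number from compound 2 to compound 3 (0.12 log units; within the scatter), while a step that the limit leaves unreadable from compound 1 to compound 3 offers no reading. The expected step is therefore a 1.1-fold lower number from compound 3 to compound 4 (0.03 log units; within the scatter), nothing beyond the scatter. Compound 4 is estimated at 50000 nM, between 25000 nM and 100000 nM.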

Compound 4, half-maximal inhibitory concentration: > 50000 nM
Compound 4 was reported as a limit (the forecaster's own chance of this, stated with the estimate: 40%); the middle value lies on the limit itself.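

In this assay, going by these compounds alone, compound 4 gives a limit rather than a number, so a ring-bearing carboxylic acid at this position adds a second compound without an exact reading: the limit of > 50000 nM in this assay, at which 2 of the 4 values shown sit. The only readable comparison is an at least 1.2-fold higher number from compound 2 to compound 4 (0.08 log units; that floor lies within the scatter), which shows no difference beyond the scatter for (2-carboxypiperidin-1-yl)methyl in place of formyl. The steps from compound 3 and from compound 1 to compound 4 cannot be read. On these data alone, the actual number for compound 4 stays open. So does the reading for a plain piperidin-1-yl group, without the carboxylic acid, at this position.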